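Alkyl Imine Variation on a Shared Core

The compounds below may be only part of what the source reports. "The series", "measured", "known", "first", "only" and "open" are said of these compounds alone.

Measured so far:
compound 1 `C/C(=N\Cc1ccccc1)c1c(O)c2ccccc2[nH]c1=O` — >= 100000 nM
compound 2 `C/C(=N\C(C)C)c1c(O)c2ccccc2[nH]c1=O` — >= 100000 nM

In an assay on isolated protein for inhibition of myosin-2 (Bos taurus), read by spectrophotometry, with a stated time of 24 min (on this read-out lower numbers stand for stronger inhibition and higher numbers for weaker inhibition), compound 1 gives only a limit, >= 100000 nM. Compound 2 likewise gives only a limit in this assay, >= 100000 nM. The step that the two limits leave unreadable from compound 1 to compound 2 is therefore not readable in size. Compound 2 thus stands at the limit of >= 100000 nM in this assay, at which 2 of the 2 values shown sit, and no number places it more closely.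

Compound 3 `CCC(C)/N=C(\C)c1c(O)c2ccccc2[nH]c1=O` differs from compound 2 by methyl in place of hydrogen on a saturated chain carbon, two bonds along the chain from a double-bonded nitrogen. Among the measured compounds shown here, the only measured step that touches this part of the molecule is a step that the two limits leave unreadable from compound 1 to compound 2, and it is unreadable, so no measured step gives a size or a direction for the move from compound 2 to compound 3. The expectation for compound 3 in this assay is therefore set at the same limit, estimated at 100000 nM with a range from 30000 nM to 300000 nM, which amounts to an expected step of a number no higher from compound 2 to compound 3 (the limit leaves the size open).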

Compound 3, half-maximal inhibitory concentration: >= 100000 nM
Compound 3 was reported as a limit; the forecaster's own chance of this, stated with the estimate: 85%; the middle value sits exactly at the limit.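

In this assay compound 3 also gives >= 100000 nM as a limit and not a number. Among the compounds shown here, no step among compound 1, compound 2 and compound 3 can therefore be read. The compounds shown leave open how strongly each inhibits myosin-2, and whether the group on the double-bonded nitrogen changes that.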